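One Group Exchanged in a Permeability Series

The source may report more compounds than this note shows. Statements on the series, on what has been measured and on what is new or still open speak of the compounds shown alone.

Of the compounds shown here, three have been measured so far in an ADME assay on Caco-2 cells (Homo sapiens) for permeability, tested at 50 uM (on this read-out higher numbers stand for higher permeability and lower numbers for lower permeability), and their values are these.
- compound 1 `COc1cc(C)c(S(=O)(=O)N(C)CCOCC(=O)N2CCC(C(C)(C)CN(C)C)CC2)c(C)c1` gives 13.6 10^-6 cm/s
- compound 2 `COc1cc(C)c(S(=O)(=O)N(C)CCOCC(=O)N2CCN(C3CCN(C4CC4)CC3)CC2)c(C)c1` gives 11.8 10^-6 cm/s
- compound 3 `COc1cc(C)c(S(=O)(=O)N(C)CCOCC(=O)N(C)Cc2ccc(C3=NCCN3)cc2)c(C)c1` gives 1.3 10^-6 cm/s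

Compound 1 at 13.6 10^-6 cm/s and compound 2 at 11.8 10^-6 cm/s lie within the usual scatter of each other, so the two share the top of this small set. Compound 3 at 1.3 10^-6 cm/s lies lower than compound 1 by far more than that scatter.

The next compound to be read is compound 4 `COc1cc(C)c(S(=O)(=O)N(C)CCOCC(=O)N2CCC(CN3CCN(C)CC3)CC2)c(C)c1` which keeps the core of compound 1 and changes one group. It carries (4-methylpiperazin-1-yl)methyl in place of 1-((dimethylamino)methyl)-1-methylethyl on a saturated ring carbon and nothing else differs.

For the measured compounds named here, no measured pair isolates this exchange, so the data give no direct size for it. Going by the values given here, the only guide is that compound 1 at 13.6 10^-6 cm/s and compound 2 at 11.8 10^-6 cm/s agree despite carrying different groups on the shared core. A small downward move that stays within the scatter is therefore expected, and the estimated step is a 1.4-fold lower number from compound 1 to compound 4 (0.13 log units; within the scatter) in this assay for now. For compound 4 the expected value is 10 10^-6 cm/s with an estimated range from 4.5 10^-6 cm/s to 20 10^-6 cm/s in this measurement.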

Compound 4, apparent permeability: 4.8 10^-6 cm/s
Estimate against measurement, compound 4: 2.1-fold (0.32 log units) above; low and high end bracket the measured number.
By their numbers in this assay, from the lowest: compound 3; then compound 4; then compounds 2 and 1 (each within the scatter of the next).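

In this assay, for the compounds shown here, putting (4-methylpiperazin-1-yl)methyl in place of 1-((dimethylamino)methyl)-1-methylethyl on a saturated ring carbon gives the first size for a change in one place, a 2.8-fold lower number from compound 1 to compound 4 (0.45 log units; beyond the scatter), and so a step beyond the usual scatter. It shows that the number in this assay does respond to the group at this position, at least when a group with no ring leaves and one with a six-membered non-aromatic ring with 2 hetero atoms enters. No measurement at hand accounts for the size of this step.

The compounds shown leave open which part of the exchange carries the step, since the two groups differ at once in ring, in nitrogen count and in hydrogen-bond acceptors. They also leave open how a (morpholin-4-yl)methyl group or a plain (dimethylamino)methyl group would read on the same ring carbon in this assay, and so whether the step belongs to the piperazine ring itself or to the loss of the group that left.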